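The compounds below may be only part of what the source reports. "The series", "measured", "known", "first", "only" and "open" are said of these compounds alone.

Compound 1 `COc1ccc(N)c(C2=NN(C(C)=O)C(C)(C)S2)c1` gives 77.1% in an assay on isolated protein for inhibition of Nitric oxide synthase, inducible (Homo sapiens), read by scintillation counting, with a stated time of 30 min, tested at 50 uM; a higher number here means more inhibition at the concentration tested (going by the name of the read-out), a lower number less inhibition. Compound 2 `CCC(=O)N1N=C(c2cc(OC)ccc2N)SC1(C)C` carries methyl in place of hydrogen on a saturated chain carbon bound to a carbonyl carbon and gives 73% in this assay, so the step of a number 4.1 percentage points lower from compound 1 to compound 2 (within the scatter) is small. Compound 3 `CCC(=O)N1N=C(c2cc(Cl)ccc2N)SC1(C)C` gives 1.07% in this assay, and the step of a number 71.9 percentage points lower from compound 2 to compound 3 (beyond the scatter) is the largest among these three. Compound 3 and compound 1 differ in more than one place, and the difference between the two cores is not broken down here. Compound 4 `CCCC(=O)N1N=C(c2cc(Cl)ccc2N)SC1(C)C` has not yet been tested; it carries methyl in place of hydrogen on a saturated chain carbon, two bonds along the chain from a carbonyl carbon. Going by the values given here, this is the same kind of change as the one from compound 1 to compound 2, though the place differs: there the methyl entered on a saturated chain carbon bound to a carbonyl carbon, here on a saturated chain carbon two bonds along the chain from a carbonyl carbon. Compound 4 is expected to show a number 1.9 percentage points higher from compound 3 to compound 4 (within the scatter), set beside the earlier a number 4.1 percentage points lower from compound 1 to compound 2 (within the scatter), because compound 3 already gives 1.07% and a similar methyl step stayed within the scatter. Compound 4 is therefore estimated at 3%, between 0% and 15%.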

Compound 4, a percentage reported as inhibition, at one concentration (the size of the read-out at that concentration, not a potency): 66.2%
Beside the measured number, compound 4's estimate is 63.2 percentage points below it; the measured number lies above the stated range.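

In this assay, methyl in place of hydrogen on a saturated chain carbon, two bonds along the chain from a carbonyl carbon, goes with a number 65.1 percentage points higher from compound 3 to compound 4 (beyond the scatter), and set beside the earlier step this shows that the size of a methyl step does not carry from one core to the other: the same change on two cores in this assay, a number 4.1 percentage points lower (within the scatter) from compound 1 to compound 2 and a number 65.1 percentage points higher (beyond the scatter) from compound 3 to compound 4, 69.2 percentage points apart, beyond the scatter of two such steps The two steps also differ in place, since the earlier methyl entered on a saturated chain carbon bound to a carbonyl carbon, and the data do not separate the effect of the core from that of the place. Going by these compounds alone, with only one step on each core and each number read at a single concentration, they show no general rule for chain length on either core.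

The compounds shown leave open how the core of compound 1 would respond to the propylcarbonyl group of compound 4. They also leave open whether, on the core of compound 4, a longer chain or an amine at the end of the chain would hold this level of inhibition.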